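From 3-chlorophenyl to 2-fluorophenyl on the ethenyl chain

The compounds below may be only part of what the source reports. "The series", "measured", "known", "first", "only" and "open" are said of these compounds alone.

Compound 1 `Cc1cc(=O)c2c(O)c(CN3CCCC3CO)c(O)c([C@H]3CCN(C)C[C@H]3O)c2o1` gives 19%
Compound 2 `CN1CC[C@H](c2c(O)cc(O)c3c(=O)cc(/C=C/c4cccc(Cl)c4)oc23)[C@H](O)C1` gives 55%

In a functional assay on Caco-2 cells (Homo sapiens) for inhibition, read by MTT assay, with a stated time of 48 h, tested at 10 uM (a higher number here means more inhibition of growth at the concentration tested, a lower number less inhibition of growth), compound 2 gives 55% as the higher of the two numbers. Compound 1 lies lower at 19% and that gap is beyond the scatter. Compound 3 `CN1CC[C@H](c2c(O)cc(O)c3c(=O)cc(/C=C/c4ccccc4F)oc23)[C@H](O)C1` differs from compound 2 in one place 2-fluorophenyl in place of 3-chlorophenyl on a double-bonded chain carbon bound to a double-bonded chain carbon with 2-fluorophenyl in place of 3-chlorophenyl on a double-bonded chain carbon bound to a double-bonded chain carbon. Going by the values given here, no measured pair shows this exchange, so the expectation rests on compound 2 at 55% alone. In this assay the expected size is a number 7 percentage points lower from compound 2 to compound 3 (within the scatter) and this estimated step is a slight fall that stays within the scatter. Compound 3 is estimated at 48% with an expected range from 30% to 65% around it.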

Compound 3, percent growth inhibition at one concentration: 68%
The estimate for compound 3 lay 20 percentage points below the measured number; measured number above the stated range.
By their numbers in this assay, from the lowest: compound 1; then compound 2; then compound 3.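

In this assay the exchange of 3-chlorophenyl for 2-fluorophenyl on a double-bonded chain carbon bound to a double-bonded chain carbon gives a number 13 percentage points higher from compound 2 to compound 3 (beyond the scatter) and so shows that the number responds to the group carried at this place on the chain. The two groups match in heavy atoms, in their aromatic ring of carbon only and in net charge, so the rise comes with a change that leaves these counts untouched. The halogen and its numbered place on the phenyl ring change together in this one step, which therefore cannot assign the rise to either alone.

On these data alone, how 2-chlorophenyl, 3-fluorophenyl, a phenyl ring carrying an amine or a carboxylic acid, or a longer chain would read in this assay remains open. Nothing in the data given explains the rise.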